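This account rests on a few compounds, and the source may have more. Where it says the series, first, only, none or still open, it means among the compounds named here.

Working notes on the series. Compound 1 `COc1cc(C)cc(-c2c(-c3ccnc(-c4ccc(C(C)=O)cc4)c3)cnn2CC#N)c1` is measured in a functional assay on U-251 cells (Homo sapiens) for inhibition, read by sulforhodamine B assay, with a stated time of 48 h (on this read-out lower numbers stand for stronger inhibition of growth and higher numbers for weaker inhibition of growth), and gives 2890 nM. Compound 2 `Cc1cc(O)cc(-c2nn(CC#N)cc2-c2ccnc(-c3ccc(Oc4ccccc4)cc3)c2)c1`, which carries a different set of groups on the same core, gives in this assay 1610 nM. Among the measured compounds shown here, only these two numbers exist so far, and they lie within the usual scatter of each other, so compound 1 does not stand apart from compound 2 on what has been measured; no pair of measured compounds differs in a single place, and there is therefore no calibrated single-point step to lean on.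

Compound 3 `COc1cc(C)cc(-c2c(-c3ccnc(-c4ccc(N(C)C)cc4)c3)cnn2CC#N)c1` is the next compound to be measured in this assay. It differs from compound 1 in one place: dimethylamino in place of acetyl on an aromatic carbon. Nothing measured here shows how an exchange of this kind moves the read-out, so the expected step is one that stays within the scatter rather than a clear move in either direction. The step of a 1.0-fold higher number from compound 1 to compound 3 (0.02 log units; within the scatter) is estimated to be of that size. Compound 3 is expected to give about 3000 nM, with a range from 1200 nM to 8000 nM.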

Compound 3, concentration for 50% growth inhibition: 178 nM
For compound 3 the middle estimate is 17-fold (1.23 log units) above the measured one; measured number outside the range, below it.
By their numbers in this assay, from the lowest: compound 3; then compounds 2 and 1 (each within the scatter of the next).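

In this assay, among the compounds shown here, the place on the six-membered aromatic ring of carbon only, para to a large group, proves sensitive to the group it carries: with the rest of the molecule unchanged, dimethylamino in place of acetyl gives a 16-fold lower number from compound 1 to compound 3 (1.21 log units; beyond the scatter), a large step well beyond the scatter and the first calibrated single-point change. The two groups have the same heavy-atom count and the same hydrogen-bond acceptor count and neither has a donor, so these counts do not separate them; what differs is that a carbonyl with its oxygen leaves and a nitrogen enters, and a change of this size therefore occurs between groups that match on those counts. No measurement available here accounts for the step.

On these data alone, whether the step is specific to dimethylamino or also appears with a primary amine, a methoxy group or a morpholine at this place remains open. As far as these compounds go, it is equally open whether the same exchange gives a step of this size with other groups elsewhere on the shared core, as this is a single pair on a single background.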